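Reshaping the Sulfonylated Ring of Compound 1

This account rests on a few compounds, and the source may have more. Where it says the series, first, only, none or still open, it means among the compounds named here.

Measured so far in an ADME assay on MT4 cells (Homo sapiens) for cytotoxicity, read by MTT assay; a lower number here means that less compound is tolerated, a higher number that more compound is tolerated:
- compound 1 `Cc1cc(C#N)cc(C)c1Oc1ccnc(Nc2ccc(CN3CCCN(S(C)(=O)=O)CC3)cc2)n1`: 7850 nM
- compound 2 `Cc1cc(/C=C/C#N)cc(C)c1Oc1ccnc(Nc2ccc(CN3CCCN(S(C)(=O)=O)CC3)cc2)n1`: 17400 nM
- compound 3 `Cc1cc(C#N)cc(C)c1Oc1ccnc(Nc2ccc(CN3CCCN(S(=O)(=O)N(C)C)CC3)cc2)n1`: 4190 nM

Compound 1 stands second highest of the three numbers. Its nearest neighbour is compound 3, with a 1.9-fold lower number from compound 1 to compound 3 (0.27 log units; within the scatter), a step that stays within the scatter; its furthest is compound 2, with a 2.2-fold higher number from compound 1 to compound 2 (0.35 log units; beyond the scatter), a step beyond it.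

Compound 4 `CCS(=O)(=O)N1CCN(Cc2ccc(Nc3nccc(Oc4c(C)cc(C#N)cc4C)n3)cc2)CC1` holds the same atoms as compound 1, joined differently: 4-(ethylsulfonyl)piperazin-1-yl in place of 4-(methylsulfonyl)-1,4-diazepan-1-yl on a saturated chain carbon bound to an aromatic carbon. Going by the values given here, of the measured steps, only the one from compound 1 to compound 3 touches the same region, the group on the sulfonyl sulfur, and that step was a 1.9-fold lower number from compound 1 to compound 3 (0.27 log units; within the scatter). The step from compound 1 to compound 2 alters the nitrile end of the molecule and says nothing about this change. Among the compounds with values here, no measured step alters the size of the saturated ring, so the contraction is untested here.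

On that basis the step to compound 4 in this assay is expected to be small, estimated as a 1.1-fold lower number from compound 1 to compound 4 (0.05 log units; within the scatter). Compound 4 is therefore estimated at 7000 nM, with a range from 3000 nM to 17000 nM.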

Compound 4, half-maximal cytotoxic concentration: 5240 nM
Compound 4: middle estimate off by 1.3-fold (0.13 log units), on the high side; the measured number falls inside the stated range.
By their numbers in this assay, from the lowest: compounds 3, 4 and 1 (each within the scatter of the next); then compound 2.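

In this assay, going by these compounds alone, this is the first measured change to the saturated ring itself, and rejoining the same atoms as 4-(ethylsulfonyl)piperazin-1-yl gives a 1.5-fold lower number from compound 1 to compound 4 (0.18 log units; within the scatter). The seven-membered ring of compound 1 and the six-membered ring of compound 4 therefore cannot be told apart in this assay, although the change alters both the ring and the chain on the sulfonyl sulfur, so the share of each cannot be read. Nothing available explains this result.

The compounds shown leave open what each part of the change does alone, which 4-(methylsulfonyl)piperazin-1-yl or 4-(ethylsulfonyl)-1,4-diazepan-1-yl would separate. They also leave open whether the sulfonyl group matters at all, a question that an acetyl group in its place could address.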